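Tolerated Dose of a Bulkier Amine Side Chain

The source may hold more compounds than are shown below. What is called first, only, known or untested is meant among the compounds shown, and "the series" means these compounds.

Three compounds have been measured in an ADME assay on Vero 76 cells (Chlorocebus sabaeus) for cytotoxicity, read by microscopy; a higher number here means that more compound is tolerated, a lower number that less compound is tolerated:
Compound 1 `CC(C)C(Nc1nc(Cl)nc2c1ncn2[C@H]1[C@H](O)[C@H](O)[C@]2(CO)C[C@H]12)C(C)C` gives > 100000 nM.
Compound 2 `CC(C)(O)[C@@H](Nc1nc(Cl)nc2c1ccn2[C@H]1[C@H](O)[C@H](O)[C@]2(CO)C[C@H]12)C1CC1` gives > 100000 nM.
Compound 3 `OC[C@H]1O[C@@H](n2cnc3c(NC(C4CCC4)C4CCC4)nc(Cl)nc32)[C@H](O)[C@@H]1O` gives 32000 nM.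

For compound 1 the value is a limit of the assay, not a number, (the limit of > 100000 nM in this assay, at which 2 of the 3 values shown sit). For compound 2 the value is likewise a limit of the assay. Compound 3 alone gives a number below that limit. No two of the measured compounds differ in only one place, so no measured step can be read from them.

Compound 4 `CC(C)(C)[C@H](Nc1nc(Cl)nc2c1ncn2[C@H]1[C@H](O)[C@H](O)[C@]2(CO)C[C@H]12)C1CC1` is built from compound 1 by 1-cyclopropyl-2,2-dimethylpropyl in place of 1-isopropyl-2-methylpropyl on a nitrogen on an aromatic ring. Because compound 1 sits at the limit of > 100000 nM in this assay, at which 2 of the 3 values shown sit, the step of a number no higher from compound 1 to compound 4 (the limit leaves the size open) is expected to be none beyond the scatter. Compound 4 is therefore estimated at 100000 nM, between 30000 nM and 300000 nM.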

Compound 4, half-maximal cytotoxic concentration: > 100000 nM
Compound 4 was reported as a limit; the forecaster's own chance of this, stated with the estimate: 70%; the middle value sits exactly at the limit.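

Compound 1 and compound 4 are both reported only as limits, so no step between them can be read: the limit of > 100000 nM in this assay, at which 3 of the 4 values shown sit.

Going by these compounds, how far past that limit either compound would fall in this assay, and whether swapping the side chain changes anything there, stays open.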